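A Halogen Swap on the Triazole Aryl Ring

The source may hold more compounds than are shown below. What is called first, only, known or untested is meant among the compounds shown, and "the series" means these compounds.

Going by the values given here, compound 1 `C=C1C(=O)[C@]23C[C@@]1(O)CC[C@H]2c1ccc(OS(=O)(=O)c2ccc(C)cc2)c(C)c1[C@@H]3Cn1cc(-c2ccc(Br)cc2)nn1` is the only member of this set with a measured number in a functional assay on SW480 cells (Homo sapiens) for cytotoxicity, read by MTT assay, with a stated time of 4 days (on this read-out lower numbers stand for stronger inhibition and higher numbers for weaker inhibition), where compound 1 gives 1590 nM. Compound 2 `Cc1c(O)ccc2c1[C@H](Cn1cc(-c3ccc(F)cc3)nn1)[C@@]13CC(=O)[C@@](C)(CC[C@@H]21)C3` returns only a limit, > 20000 nM. Compound 3 `C=C1C[C@]23C[C@@]1(O)CC[C@@H]2c1cccc(C)c1[C@@H]3Cn1cc(-c2ccc(Cl)cc2)nn1` likewise returns only a limit, > 20000 nM. Compound 1 therefore stands alone against (the limit of > 20000 nM in this assay, at which 2 of the 3 values shown sit). Compound 4 `C=C1C(=O)[C@]23C[C@@]1(O)CC[C@H]2c1ccc(OS(=O)(=O)c2ccc(C)cc2)c(C)c1[C@@H]3Cn1cc(-c2ccc(F)cc2)nn1` is not yet measured; it differs from compound 1 by fluoro in place of bromo on an aromatic carbon. Among the compounds with values here, no measured pair isolates this exchange, so the expected step from compound 1 to compound 4 in this assay is a modest weakening, a 1.8-fold higher number from compound 1 to compound 4 (0.25 log units; within the scatter), barely beyond the scatter. Compound 4 is accordingly estimated at 2800 nM, within 1000 nM to 9000 nM.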

Compound 4, half-maximal inhibitory concentration: 1630 nM
The estimate for compound 4 lay 1.7-fold (0.23 log units) above the measured number; the measured number falls inside the stated range.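

Going by these compounds alone, the pair gives the first reading of a single exchange on the triazole aryl ring: 4-bromophenyl to 4-fluorophenyl in this assay gives a 1.0-fold higher number from compound 1 to compound 4 (0.01 log units; within the scatter). With the rest of the structure held constant, the two halogens at this position cannot be told apart in this cell read-out. Nothing shown accounts for this result.

The compounds shown leave open whether an amine or a carboxylic acid in place of the halogen would leave the value as unchanged. They also leave open how a methoxy group there would read.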